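Sulfanyl for Hydroxy on a Core Without Measurable Inhibition

This account rests on a few compounds, and the source may have more. Where it says the series, first, only, none or still open, it means among the compounds named here.

Measured compounds:
compound 1, `Cc1nc(-c2ccccc2)n2c(S)nncc12`: > 48000 nM
compound 2, `C=CCSc1nncc2cnc(-c3ccccc3)n12`: > 48000 nM
compound 3, `Oc1nncc2cnc(-c3ccccc3)n12`: > 48000 nM

Three compounds of a shared core were tested in a functional assay for inhibition, with Homo sapiens as the target; a higher number here means a weaker inhibitor, a lower number a stronger inhibitor. For compound 1 the value > 48000 nM is a limit of the assay, not a number. For compound 2 the value > 48000 nM is likewise a limit. For compound 3 the value > 48000 nM is again a limit. Compound 3 thus stands at the limit, and so do the two other measured values; (the limit of > 48000 nM in this assay, at which 3 of the 3 values shown sit). For the measured compounds named here, the single step among measured compounds, a step that the two limits leave unreadable from compound 2 to compound 3, has no readable size since both of its ends are limits.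

Compound 4, `Sc1nncc2cnc(-c3ccccc3)n12`, differs from compound 3 by sulfanyl in place of hydroxy on an aromatic carbon. Going by the values given here, no measured step bears directly on this change, and the one measured step gives no size. Compound 1, which also carries a sulfanyl group, sits at the limit. Nothing in the data points to a move away from the limit in this assay, so no step beyond the scatter is expected. Compound 4 is therefore expected to give 80000 nM, with a range from 30000 nM to 250000 nM. The expected step is a step that the limit leaves unreadable from compound 3 to compound 4, most likely reported as a limit rather than a number.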

Compound 4, half-maximal inhibitory concentration: > 48000 nM
Compound 4: a limit, no number; the forecaster's own chance of this, stated with the estimate: 90%; the middle value is on the limit's open side.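

In this assay compound 4 gives > 48000 nM, which is a limit and not a number. For the compounds shown here, no step from compound 1, compound 2 or compound 3 to compound 4 can be read, and the values offer only this: the limit of > 48000 nM in this assay, at which 4 of the 4 values shown sit. The compounds shown leave open whether any change on the shared core gives a measurable half-maximal inhibitory concentration.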